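Fluoro to isopropyl: compound 3 to compound 4

The source may report more compounds than this note shows. Statements on the series, on what has been measured and on what is new or still open speak of the compounds shown alone.

Compound 3 `CC(C)(C)Cc1c(-c2ccc(F)cc2)sc(N)c1C(=O)c1ccc(Cl)cc1` was tested in an assay on CHO cells for displacement of a labelled ligand from adenosine receptor A1 (Homo sapiens), read by scintillation counting, tested at 10 uM (on this read-out higher numbers stand for more inhibition at the one concentration tested (going by the name of the read-out) and lower numbers for less inhibition), where compound 3 gives 1%. Compound 1 `Cc1c(Br)sc(N)c1C(=O)c1ccc(Cl)cc1` gives 1% in this assay, level with compound 3 at the digits shown; together they are the lowest of the three numbers. Compound 2 `CC(C)(C)Cc1csc(N)c1C(=O)c1cccc(Cl)c1` gives 2% in this assay, within the scatter of compound 3. Compound 4 `CC(C)c1ccc(-c2sc(N)c(C(=O)c3ccc(Cl)cc3)c2CC(C)(C)C)cc1` is not yet measured; it differs from compound 3 by isopropyl in place of fluoro on an aromatic carbon. Among the measured compounds shown here, no step between measured compounds is available, so no comparable exchange has been seen in this set. All three measured compounds sit at the bottom of the read-out, and the exchange is expected to give a step within the scatter, with no direction beyond it: a number 1 percentage points higher from compound 3 to compound 4 (within the scatter). For compound 4 the estimate is 2%, with a range from -8% to 12%.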

Compound 4, a percentage reported as inhibition, at one concentration (the size of the read-out at that concentration, not a potency): 1%
Estimate against measurement, compound 4: 1 percentage points above, within the range that was stated.
By their numbers in this assay, from the lowest: compounds 1, 3, 4 and 2 (each within the scatter of the next).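

In this assay, isopropyl in place of fluoro gives no change at the digits printed from compound 3 to compound 4 (within the scatter), the first step read in this set. On this aromatic carbon, the exchange of fluoro for isopropyl, with 3 heavy atoms in place of 1, therefore leaves the number within the scatter, and with values this low a further loss could hardly show. Nothing at hand explains this flat step. On these data alone, whether an amine or a carboxylic acid on this aromatic carbon would give a number clear of the scatter remains open.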